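This account rests on a few compounds, and the source may have more. Where it says the series, first, only, none or still open, it means among the compounds named here.

Four compounds share one core, an acid-bearing bicyclic unit linked through an ether to a five-membered aromatic ring that carries a methyl group and a further aromatic group. Compound 1 `Cc1nc(-c2ccsc2)sc1COc1ccc2c(c1)OCC2CC(=O)O` carries thiophen-3-yl there, and in a functional assay on CHO cells for agonist activity at Free fatty acid receptor 1 (Homo sapiens), read by FLIPR and calcium flux (a higher number here means that more compound is needed for the effect, a lower number that less compound is needed), compound 1 gives 68.5 nM. Compound 3 `Cc1nc(-c2ccc(Cl)cc2)sc1COc1ccc2c(c1)OCC2CC(=O)O` carries 4-chlorophenyl instead, and in this assay compound 3 gives 85.6 nM. Going by the values given here, the single step between them, a 1.2-fold higher number from compound 1 to compound 3 (0.10 log units; within the scatter), shows that swapping a five-membered sulfur-containing ring for a six-membered carbon ring at this position barely moves the read-out.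

Compound 2 `Cc1nc(-c2ccc(Cl)s2)sc1COc1ccc2c(c1)OCC2CC(=O)O` carries 5-chlorothiophen-2-yl; for compound 2 the result in this assay is "not determined" (no result reported), so compound 2 stands nowhere on the numbers, and it cannot anchor the next step. Compound 4 `Cc1nc(-c2cccc(F)c2)sc1COc1ccc2c(c1)OCC2CC(=O)O` differs from compound 2 in one place: 3-fluorophenyl in place of 5-chlorothiophen-2-yl on an aromatic carbon.

Among the compounds with values here, only the step from compound 1 to compound 3 bears on this change, and it was within the scatter, so no shift beyond the scatter is expected in this assay for compound 4. Because compound 1 gives 68.5 nM and compound 3 gives 85.6 nM, compound 4 is expected to land near them, at an estimated 80 nM, within a range from 35 nM to 180 nM.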

Compound 4, half-maximal effective concentration: 64.8 nM
Compound 4: middle estimate off by 1.2-fold (0.09 log units), on the high side, and the stated range covers the measured number.
By their numbers in this assay, from the lowest: compounds 4, 1 and 3 (each within the scatter of the next).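

In this assay, replacing the aromatic group on the five-membered ring gives a 1.3-fold lower number from compound 3 to compound 4 (0.12 log units; within the scatter) and also a 1.1-fold lower number from compound 1 to compound 4 (0.02 log units; within the scatter), and both steps lie within the scatter. Thiophen-3-yl, 4-chlorophenyl and 3-fluorophenyl therefore cannot be told apart at this position, which extends the earlier single comparison to a third group and shows that a different halogen, placed elsewhere on the phenyl ring, leaves the read-out within the scatter; the step from compound 2 to compound 4 cannot be read, as compound 2 has no number. Nothing available explains why these three groups read alike.

The compounds shown leave open whether this position accepts groups other than the three read here, such as a pyridine ring, a cyclohexyl ring or a morpholine ring, and where 5-chlorothiophen-2-yl would stand. They also cannot show what the methyl group or the carboxylic acid contributes, since both stay the same in compounds 1, 3 and 4.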